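A few compounds are considered here, and "the series" means these few. Any claim that something is new, unique, unknown or untested is made for them only; others in the source may bear on it.

In a functional assay on MCF7 cells (Homo sapiens) for antiproliferative activity, read by sulforhodamine B assay, with a stated time of 48 h (on this read-out higher numbers stand for weaker inhibition of growth and lower numbers for stronger inhibition of growth), three related compounds have been measured. Among them, compound 1 `CCCCCCCC/C=C\CCCCCCCC(=O)N1CCCC1` gives 5.2 ug/mL, the second highest number. Compound 3 `CCCCCCCCCCCCCCCC(=O)N1CCOCC1` reads higher at 15.4 ug/mL, while compound 2 `CCCCCCCCCCCCCCCCCC(=O)N[C@H](C)c1ccccc1` reads much lower at 0.06 ug/mL, and both gaps from compound 1 lie beyond the scatter.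

Still unmeasured is compound 4 `CCCCCCCC/C=C\CCCCCCCC(=O)N1CCOCC1`, which differs from compound 1 in one place: morpholin-4-yl in place of pyrrolidin-1-yl on a carbonyl carbon. Going by the values given here, no measured pair isolates this change, so the evidence is indirect. Compound 3 also carries morpholin-4-yl on a carbonyl carbon, although its chain differs, and compound 3 gives 15.4 ug/mL. On that single comparison, a modest move towards a higher number, meaning weaker inhibition of growth, is expected in this assay. The expected step is a 1.7-fold higher number from compound 1 to compound 4 (0.24 log units; within the scatter), which may well stay within the scatter. For compound 4 the estimated value is 9 ug/mL, with an expected range of 3.5 ug/mL to 22 ug/mL.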

Compound 4, concentration for 50% growth inhibition: 4.9 ug/mL
Estimate against measurement, compound 4: 1.8-fold (0.26 log units) above, and the stated range covers the measured number.
By their numbers in this assay, from the lowest: compound 2; then compounds 4 and 1 (each within the scatter of the next); then compound 3.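

Going by these compounds alone, this is the first direct reading of this change: with the chain of compound 1 kept, morpholin-4-yl in place of pyrrolidin-1-yl on a carbonyl carbon gives a 1.1-fold lower number from compound 1 to compound 4 (0.03 log units; within the scatter) in this assay and stays within the scatter. The larger six-membered ring and its one hydrogen-bond acceptor therefore leave no readable mark on this read-out at this position. Compound 3 gives 15.4 ug/mL and morpholin-4-yl on this carbonyl carbon thus does not by itself go with that number. Nothing measured here speaks to why the step is so small.

Still open, from the compounds shown here alone, is how piperidin-1-yl or piperazin-1-yl would read on this carbonyl carbon. Going by these compounds, it is also open whether a 1-phenylethylamino group on the chain of compound 1 would bring the number nearer to that of compound 2.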